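Swapping a Benzyloxy for a Dichloroanilino Group

The source may report more compounds than this note shows. Statements on the series, on what has been measured and on what is new or still open speak of the compounds shown alone.

Measured so far:
compound 1, `C=C[C@@](C)(/C=C/c1ccc(OCc2ccccc2)cc1)CCC=C(C)C`: > 36600 nM
compound 2, `COc1ccc(/C=C/[C@@](C)(/C=C/c2ccc(O)c(/C=C/C(=O)OC(C)(C)C)c2)CCC=C(C)C)cc1`: > 36600 nM
compound 3, `CC(C)=CCC[C@](C)(/C=C/c1ccc(O)cc1)/C=C/c1cccc(Cl)c1`: > 36600 nM

All three compounds were tested in an ADME assay on BJ cells (Homo sapiens) for cytotoxicity, with a stated time of 72 h; a lower number here means that less compound is needed, a higher number that more compound is needed for the effect. In this assay compound 1 gives only a limit, > 36600 nM, not a number. Compound 2 likewise gives only a limit, > 36600 nM. Compound 3 also gives only a limit, > 36600 nM. Compound 1 therefore stands where every measured compound stands: the limit of > 36600 nM in this assay, at which 3 of the 3 values shown sit. Going by the values given here, no step between measured compounds is available, so nothing is known about how far a single change can move this value.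

Compound 4, `C=C[C@@](C)(/C=C/c1ccc(Nc2ccc(Cl)c(Cl)c2)cc1)CCC=C(C)C`, has not yet been measured. It differs from compound 1 in one place: (3,4-dichlorophenyl)amino in place of benzyloxy on an aromatic carbon. The entering (3,4-dichlorophenyl)amino group carries one hydrogen-bond donor, which the benzyloxy group lacked.

Because compound 1 gives only a limit > 36600 nM, the step of an at least 1.2-fold lower number from compound 1 to compound 4 (0.08 log units; that floor lies within the scatter) is expected to be small, towards a lower number if anything, and most likely within the scatter. Compound 4 is expected to give about 30000 nM, between 8000 nM and 80000 nM, with a good chance that only a limit is reported again.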

Compound 4, half-maximal effective concentration: > 36600 nM
Compound 4: only a limit was reported (the forecaster's own chance of this, stated with the estimate: 60%); at least 1.2-fold (0.08 log units) between middle value and limit.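

In this assay compound 1 and compound 4 each give only a limit, not a number, so the size of the step between them cannot be read. How far any single change to the shared core can move this value stays open, with every compound shown resting at the same point: the limit of > 36600 nM in this assay, at which 4 of the 4 values shown sit.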